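Fluoro on the pendant phenyl: compound 2 to compound 3

The source may report more compounds than this note shows. Statements on the series, on what has been measured and on what is new or still open speak of the compounds shown alone.

Working notes on a small series sharing one core. Compound 1 `OCc1cn2c(c1CO)CS[C@@H]2c1ccccc1` carries a hydrogen where compound 2 `OCc1c(CO)c(-c2ccccc2)n2c1CS[C@@H]2c1ccccc1` carries a phenyl on an aromatic carbon. In a functional assay on MCF7 cells (Homo sapiens) for cytotoxicity, read by MTT assay, with a stated time of 24 h (on this read-out lower numbers stand for stronger inhibition and higher numbers for weaker inhibition), compound 1 gives 70800 nM, and compound 2 gives 92600 nM. Going by the values given here, the only step so far, a 1.3-fold higher number from compound 1 to compound 2 (0.12 log units; within the scatter), is within the scatter. Compound 2 stands at the higher of the two numbers measured, with compound 1 as its nearest neighbour, but the two cannot be ordered on this evidence.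

Compound 3 `OCc1c(CO)c(-c2ccc(F)cc2)n2c1CS[C@@H]2c1ccccc1` differs from compound 2 by fluoro in place of hydrogen on an aromatic carbon. Among the compounds with values here, no measured step bears directly on a fluoro entering for hydrogen; the one step available, a 1.3-fold higher number from compound 1 to compound 2 (0.12 log units; within the scatter), concerns the entry of the phenyl itself and was within the scatter. Nothing in the measured data therefore points to a shift beyond the scatter, and the expected step is a 1.1-fold lower number from compound 2 to compound 3 (0.04 log units; within the scatter), essentially flat in this assay. Compound 3 is estimated at 85000 nM, with a range from 40000 nM to 180000 nM.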

Compound 3, half-maximal inhibitory concentration: 56700 nM
Estimate against measurement, compound 3: 1.5-fold (0.18 log units) above; measured number inside the range.
By their numbers in this assay, from the lowest: compounds 3, 1 and 2 (each within the scatter of the next).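

In this assay, going by these compounds alone, fluoro in place of hydrogen on an aromatic carbon of the phenyl, para to a large group, gives a 1.6-fold lower number from compound 2 to compound 3 (0.21 log units; within the scatter), the first reading of a substituent on the phenyl itself, and it does not separate the two compounds. The larger change, 4-fluorophenyl in place of hydrogen on the aromatic carbon of the shared core, gives a 1.2-fold lower number from compound 1 to compound 3 (0.10 log units; within the scatter), so on this read-out neither the phenyl nor the 4-fluorophenyl can be told apart from hydrogen at that carbon. No measurement at hand bears on this result.

The compounds shown leave open whether any group at this place on the phenyl can move the number beyond the scatter, since fluoro is the only substituent there and all three compounds lie within the scatter of each other. An amine, a carboxylic acid or a methoxy group at the same place, or a longer chain in place of the phenyl on the aromatic carbon, would show whether this part of the series responds at all in this assay.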